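Swapping a Branched Chain for a Methylphenyl Group

The source may report more compounds than this note shows. Statements on the series, on what has been measured and on what is new or still open speak of the compounds shown alone.

Measured so far:
- compound 1, `C=CC1=C(C(=O)NCc2ccc(C)cc2)C(c2ccc(OC)c(OC)c2)OC1`: 69100 nM
- compound 2, `C=CC1=C(C(=O)NCC(C)C)C(c2ccc(OC)cc2)OC1`: > 100000 nM

In a functional assay on QGY7701 cells (Homo sapiens) for cytotoxicity, read by MTT assay, with a stated time of 24 h (a lower number here means a stronger inhibitor, a higher number a weaker inhibitor), compound 1 gives 69100 nM. Compound 2 reaches only the assay limit of > 100000 nM, so for compound 2 no number is known, only that it sits at the limit (the limit of > 100000 nM in this assay, at which 1 of the 2 values shown sits). Compound 2 therefore stands at the weak end of what has been measured, and nothing more can be said of its exact position.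

Compound 3, `C=CC1=C(C(=O)NCc2ccc(C)cc2)C(c2ccc(OC)cc2)OC1`, is not yet measured. It differs from compound 2 by 4-methylphenyl in place of isopropyl on a saturated chain carbon bound to an amide-type nitrogen, that is, isobutyl becomes 4-methylbenzyl. The same amide side chain is present in compound 1, which does give a number in this assay. A modest gain in this assay from compound 2 to compound 3 is therefore expected, of about an at least 1.2-fold lower number from compound 2 to compound 3 (0.09 log units; that floor lies within the scatter), though a further limit result would not be surprising. Compound 3 is estimated at 80000 nM, in the range 30000 nM to 160000 nM.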

Compound 3, half-maximal inhibitory concentration: 43100 nM
Beside the measured number, compound 3's estimate is 1.9-fold (0.27 log units) above it; the range from low to high includes it.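

In this assay, 4-methylphenyl in place of isopropyl on a saturated chain carbon bound to an amide-type nitrogen gives an at least 2.3-fold lower number from compound 2 to compound 3 (0.36 log units; beyond the scatter), so this side-chain position does respond to the change from isobutyl to 4-methylbenzyl. The other comparison, hydrogen in place of methoxy on an aromatic carbon, gives a 1.6-fold lower number from compound 1 to compound 3 (0.21 log units; within the scatter), so these two compounds cannot be told apart and that methoxy shows no readable effect here. The true size of the side-chain step remains unknown, because only a limit is available for compound 2: the limit of > 100000 nM in this assay, at which 1 of the 3 values shown sits.

As far as these compounds go, it remains open whether the gain comes from the aromatic ring itself or from the methyl group on it, which a plain benzyl group would help to separate. Also open, from the compounds shown here alone, is how a longer chain, or a side chain ending in an amine or a carboxylic acid, would behave at this position.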